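The compounds below may be only part of what the source reports. "The series", "measured", "known", "first", "only" and "open" are said of these compounds alone.

In an ADME assay on CCRF-CEM cells (Homo sapiens) for antiproliferative activity, with a stated time of 48 h (a higher number here means a weaker inhibitor, a lower number a stronger inhibitor), compound 1, `C=C(Br)C(=O)Nc1ccc(C(=O)/C=C/c2ccccc2OC)cc1`, gives 580 nM. Compound 2, `C=C(Br)C(=O)Nc1ccc(C(=O)/C=C/c2ccc(OC)cc2OC)cc1`, carries one extra group; the change from compound 1 to compound 2 is methoxy in place of hydrogen on an aromatic carbon. In this assay compound 2 gives 1100 nM. The step this produced was a 1.9-fold higher number from compound 1 to compound 2 (0.28 log units; within the scatter).

Compound 3, `Nc1ccc(/C=C/C(=O)c2ccccc2)cc1`, is built on a different core, and the difference between the two cores is not broken down here. In this assay compound 3 gives 34000 nM, the highest of the three numbers, separated from both compound 1 and compound 2 by gaps that lie beyond the scatter.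

Compound 4, `COc1cccc(C(=O)/C=C/c2ccc(N)cc2)c1`, has not yet been measured. It differs from compound 3 by methoxy in place of hydrogen on an aromatic carbon. For the measured compounds named here, this is the same kind of change as the one from compound 1 to compound 2, but not the same change: in compound 2 the new methoxy sits meta to a methoxy group (2 heavy atoms) and para to a large group, whereas in compound 4 it sits meta to a large group, and the surrounding core is different as well.

Going by the values given here, with only one earlier example of this kind of change, the step expected in this assay is a 1.3-fold higher number from compound 3 to compound 4 (0.12 log units; within the scatter), resting on the earlier step of a 1.9-fold higher number from compound 1 to compound 2 (0.28 log units; within the scatter) and on compound 3 having given 34000 nM. Compound 4 is therefore expected to give about 45000 nM, most likely between 15000 nM and 120000 nM.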

Compound 4, half-maximal inhibitory concentration: 26000 nM
Compound 4: middle estimate off by 1.7-fold (0.24 log units), on the high side; the range from low to high includes it.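

In this assay, putting a methoxy in place of hydrogen on an aromatic carbon of compound 3 gave a 1.3-fold lower number from compound 3 to compound 4 (0.12 log units; within the scatter), so on this core the change had no effect that can be told apart from ordinary repeat variation. Set beside the earlier example, the two results cannot be told apart either, even though the numbers moved in opposite directions: the same change on two cores in this assay, a 1.9-fold higher number (0.28 log units; within the scatter) from compound 1 to compound 2 and a 1.3-fold lower number (0.12 log units; within the scatter) from compound 3 to compound 4, 2.5-fold (0.39 log units) apart, within the scatter of two such steps This shows that, in these two examples, the methoxy left the number within the scatter on both cores, but it does not show that the change is neutral wherever it is placed, since the two examples differ both in the core and in where the new methoxy sits, and two steps cannot separate those influences.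

The compounds shown leave open whether a different group in the same place, such as a chlorine atom, a hydroxyl group or a longer chain like ethoxy, would shift the number beyond the scatter. They also leave open whether a methoxy meta to a large group on the core of compound 1 would give a step like the one seen on the core of compound 3.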